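This account rests on a few compounds, and the source may have more. Where it says the series, first, only, none or still open, it means among the compounds named here.

Measured in a functional assay on A549 cells (Homo sapiens) for antiproliferative activity, read by MTT assay, with a stated time of 48 h; a lower number here means a stronger inhibitor, a higher number a weaker inhibitor:
Compound 1 `C/C(=C\CC/C(C)=C/CC[C@@H]1[C@@]2(C)CCC(=O)C(C)(C)[C@H]2CC[C@@]1(C)O)CC/C=C(\C)C(=O)OCc1cn(-c2cccc(F)c2)nn1`: 124000 nM
Compound 2 `C/C(=C\CC/C(C)=C/CC[C@@H]1[C@@]2(C)CCC(=O)C(C)(C)[C@H]2CC[C@@]1(C)O)CC/C=C(\C)C(=O)OCc1cn(-c2ccc(C)cc2)nn1`: > 150000 nM

Compound 2 stands at a limit of this assay, not at a number: > 150000 nM. On the values in hand, that is the limit of > 150000 nM in this assay, at which 1 of the 2 values shown sits.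

Compound 3 `C/C(=C\CC/C(C)=C/CC[C@@H]1[C@@]2(C)CCC(=O)C(C)(C)[C@H]2CC[C@@]1(C)O)CC/C=C(\C)C(=O)OCc1cn(-c2cccc(O)c2)nn1` carries 3-hydroxyphenyl in place of 4-methylphenyl on an aromatic nitrogen, the rest of the structure being unchanged: 3-hydroxyphenyl in place of 4-methylphenyl on an aromatic nitrogen. For the measured compounds named here, one measured step bears on this place: an at least 1.2-fold higher number from compound 1 to compound 2 (0.08 log units; that floor lies within the scatter). That step exchanges 4-methylphenyl and 3-fluorophenyl on the same nitrogen, and its floor lies within the scatter. Going by the values given here, no measured compound carries 3-hydroxyphenyl, so the evidence for compound 3 is indirect.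

Given an at least 1.2-fold higher number from compound 1 to compound 2 (0.08 log units; that floor lies within the scatter), no large move is expected in this assay at this place. The expected step is small and towards a lower number, and may not clear the scatter: an at least 1.2-fold lower number from compound 2 to compound 3 (0.09 log units; that floor lies within the scatter). A further reading at the limit would fit equally well. Compound 3 is estimated at 120000 nM, with an expected range of 50000 nM to 220000 nM.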

Compound 3, half-maximal inhibitory concentration: 42800 nM
Estimate against measurement, compound 3: 2.8-fold (0.45 log units) above, and the stated range ends above it.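

In this assay, the group on this aromatic nitrogen does move the read-out: 3-hydroxyphenyl in place of 4-methylphenyl gives an at least 3.5-fold lower number from compound 2 to compound 3 (0.54 log units; beyond the scatter), whereas the earlier step at this place did not clear the scatter. Replacing hydroxy with fluoro as the point of comparison, the change from 3-fluorophenyl to 3-hydroxyphenyl gives a 2.9-fold lower number from compound 1 to compound 3 (0.46 log units; beyond the scatter), so the lower number for compound 3 holds against both other aryl groups shown, and against a fully measured partner in this second step. Compound 2 stands at a limit, so the step from it gives only a floor and not a full size: the limit of > 150000 nM in this assay, at which 1 of the 3 values shown sits.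

Three compounds cannot tell whether the step follows the hydrogen-bond donor counted for 3-hydroxyphenyl or the oxygen alone, and a methoxy group or an amine on the same phenyl ring would separate these readings. Also open, from the compounds shown here alone, is whether a carboxylic acid or a longer chain ending in hydroxy on that ring would carry the read-out further than compound 3 does.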